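The source may report more compounds than this note shows. Statements on the series, on what has been measured and on what is new or still open speak of the compounds shown alone.

Measured so far:
- compound 1, `CCCC(Oc1ccc(-n2cc(OC)cn2)cc1)c1ccc(C(=O)NCCC(=O)O)cc1`, in an assay on cells for displacement of a labelled ligand from Glucagon receptor (Homo sapiens), in the presence of a further agent that is not named here (on this read-out higher numbers stand for weaker inhibition and lower numbers for stronger inhibition), compound 1 gives 4400 nM
- compound 2, `CC(C)(C)C(Oc1ccc(-n2cc(C(F)(F)F)cn2)cc1)c1ccc(C(=O)NCCC(=O)O)cc1`, in this assay compound 2 gives 170 nM

Compound 2 holds the lower of the two numbers in this assay; the gap to compound 1 is beyond the scatter. Compound 1 and compound 2 differ in two places at once, so neither place alone can be credited with that gap from the values shown.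

Compound 3, `CCCC(Oc1ccc(-n2cc(C(F)(F)F)cn2)cc1)c1ccc(C(=O)NCCC(=O)O)cc1`, is the next point. It keeps the trifluoromethyl-bearing part of compound 2 and changes only the chain: propyl in place of tert-butyl on a saturated chain carbon bound to an aromatic carbon and an oxygen on an aromatic ring. Compound 3 thus shares the chain of compound 1 and the remainder of compound 2. For the measured compounds named here, no single-change step is available for this exchange, so its weight is uncertain. Compound 3 is expected to fall between the two measured numbers, nearer compound 2 than compound 1, with a step of a 4.1-fold higher number from compound 2 to compound 3 (0.61 log units; beyond the scatter) that is beyond the scatter in the direction of weaker inhibition. The estimate for compound 3 in this assay is 700 nM, with a range from 220 nM to 2500 nM.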

Compound 3, inhibition constant: 890 nM
Beside the measured number, compound 3's estimate is 1.3-fold (0.10 log units) below it, within the range that was stated.
By their numbers in this assay, from the lowest: compound 2; then compound 3; then compound 1.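

In this assay the chain position now has a reading of its own: propyl in place of tert-butyl on a saturated chain carbon bound to an aromatic carbon and an oxygen on an aromatic ring gives a 5.2-fold higher number from compound 2 to compound 3 (0.72 log units; beyond the scatter) and so shows that this carbon's substituent matters with the trifluoromethyl group held constant. The other place can be read as well, since trifluoromethyl in place of methoxy on an aromatic carbon, with the propyl chain held constant, gives a 4.9-fold lower number from compound 1 to compound 3 (0.69 log units; beyond the scatter) in the direction of stronger inhibition. The gap between compound 1 and compound 2, which could not be divided before, therefore resolves into two single-place steps, each beyond the scatter, though no measured evidence here accounts for either one.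

From the compounds shown here alone, whether the tert-butyl step keeps its size with methoxy on the aromatic carbon stays open, as the step is read only with trifluoromethyl in place. Also open, going by these compounds, is how a cyclopropyl group or a longer chain such as pentyl would read at the chain carbon, and how a nitrile would read on the aromatic carbon.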